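The source may hold more compounds than are shown below. What is called first, only, known or untested is meant among the compounds shown, and "the series" means these compounds.

Measured compounds in an assay on isolated protein for inhibition of matrix metalloproteinase-9 (Homo sapiens); on this read-out higher numbers stand for weaker inhibition and lower numbers for stronger inhibition:
compound 1 `C=C[C@@H]1OC(c2ccc(Cl)cc2)=N[C@H]1CO` gives 33000 nM
compound 2 `C=C[C@@H]1OC(c2ccc(-c3ccccc3)cc2)=N[C@H]1CO` gives 24000 nM
compound 3 `C=C[C@@H]1OC(c2ccc(Br)cc2)=N[C@H]1CO` gives 9000 nM

Compound 3 stands at the lowest number of the three in this assay. The two steps leading to it are a 2.7-fold lower number from compound 2 to compound 3 (0.43 log units; beyond the scatter) and a 3.7-fold lower number from compound 1 to compound 3 (0.56 log units; beyond the scatter); both lie beyond the scatter, so compound 3 is the strongest inhibitor measured so far.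

Compound 4 `C=C[C@@H]1OC(c2ccc(Oc3ccccc3)cc2)=N[C@H]1CO` differs from compound 3 by phenoxy in place of bromo on an aromatic carbon. Among the measured compounds shown here, no measured step exchanges bromo for phenoxy directly. For the measured compounds named here, two steps bear on it: the exchange of chloro for phenyl, a 1.4-fold lower number from compound 1 to compound 2 (0.14 log units; within the scatter), which stays within the scatter, and the exchange of phenyl for bromo, a 2.7-fold lower number from compound 2 to compound 3 (0.43 log units; beyond the scatter), a modest drop. Read in reverse, the second step suggests that replacing bromo with an aromatic substituent gives a modestly higher number in this assay. Compound 4 is therefore expected to give 22000 nM in this assay, with a range from 8000 nM to 60000 nM. The expected step is a 2.4-fold higher number from compound 3 to compound 4 (0.39 log units; beyond the scatter), a move back toward the weaker end of the series.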

Compound 4, inhibition constant: 32000 nM
The estimate for compound 4 lay 1.5-fold (0.16 log units) below the measured number, and the stated range covers the measured number.
By their numbers in this assay, from the lowest: compound 3; then compounds 2, 4 and 1 (each within the scatter of the next).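

In this assay, among the compounds shown here, phenoxy in place of bromo on this aromatic carbon gives a 3.6-fold higher number from compound 3 to compound 4 (0.55 log units; beyond the scatter) and leaves compound 3 as the only compound set apart from the rest of the series. Phenoxy does not separate from the other two groups: a 1.3-fold higher number from compound 2 to compound 4 (0.12 log units; within the scatter) and a 1.0-fold lower number from compound 1 to compound 4 (0.01 log units; within the scatter) both stay within the scatter, so a phenyl ring attached through oxygen reads the same here as one attached directly, and the same as chloro. Nothing at hand accounts for the bromo result.

As far as these compounds go, whether the lower number of compound 3 is particular to bromo or extends to iodo or trifluoromethyl remains open. Also open, from the compounds shown here alone, is how an amine or a carboxylic acid would read at this position on the shared core.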